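A Methoxy Group Enters the Phenyl Ring of Compound 1

This account rests on a few compounds, and the source may have more. Where it says the series, first, only, none or still open, it means among the compounds named here.

Compound 1 `Cc1cc(O)c(C(C)C)cc1-c1cc(-c2ccccc2)c(C#N)c(=O)[nH]1`: 58%
Compound 2 `COc1cc(-c2cc(-c3cc(C(C)C)c(O)cc3C)[nH]c(=O)c2C#N)cc(OC)c1OC`: 82%

In a functional assay for inhibition, tested at 80 ug/mL (on this read-out lower numbers stand for a weaker effect and higher numbers for a stronger effect at the one concentration tested), compound 1 gives 58%, the lower of the two numbers. Compound 2 gives 82% in this assay, beyond the scatter above compound 1. Compound 3 `COc1cccc(-c2cc(-c3cc(C(C)C)c(O)cc3C)[nH]c(=O)c2C#N)c1` differs from compound 1 in one place: methoxy in place of hydrogen on an aromatic carbon. For the measured compounds named here, no step between measured compounds is known, so the expectation rests on the two values alone. Because compound 2, which also carries methoxy groups, shows 82%, a modest upward step is expected: a number 10 percentage points higher from compound 1 to compound 3 (within the scatter). Compound 3 is estimated at 68%, within 50% to 85%.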

Compound 3, a percentage reported as inhibition, at one concentration (the size of the read-out at that concentration, not a potency): 43%
Estimate against measurement, compound 3: 25 percentage points above; the measured number lies below the stated range.
By their numbers in this assay, from the lowest: compound 3; then compound 1; then compound 2.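

In this assay, for the compounds shown here, the change from phenyl to 3-methoxyphenyl gives a number 15 percentage points lower from compound 1 to compound 3 (beyond the scatter) and so shows, for the first time, what one methoxy does at this place, meta to a large group: the read-out falls. Compound 2 differs from compound 1 in more than one place, so it could not show this single change. Nothing measured here accounts for the step.

As far as these compounds go, whether a hydroxyl, an amine or a carboxylic acid at this same place would raise or lower the read-out stays open. Also open, from the compounds shown here alone, is how each methoxy of compound 2 contributes on its own.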